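The source may hold more compounds than are shown below. What is called first, only, known or untested is meant among the compounds shown, and "the series" means these compounds.

Compound 2 `COc1cc(C2CCN(CC(N)=O)CC2)ccc1Nc1ncc2c(O)cc(-c3ccccc3N(C)S(C)(=O)=O)n2n1` carries the shared core of compound 1 `COc1cc(C2CCN(CC(N)=O)CC2)ccc1Nc1ncc2ccc(-c3ccccc3N(C)S(C)(=O)=O)n2n1` with a hydroxy on an aromatic carbon. In an in vitro ADME assay on microsomes from liver (Rattus norvegicus, strain Sprague-Dawley) for metabolic stability, using NADPH, with a stated time of 10 min, tested at 0.5 uM (on this read-out lower numbers stand for a shorter-lived compound and higher numbers for a longer-lived compound), compound 1 gives only a limit of the assay, < 0.0834 h. In this assay compound 2 likewise returns only a limit, < 0.0834 h. Both values sit at the limit of < 0.0834 h in this assay, at which 2 of the 2 values shown sit, so the step that the two limits leave unreadable from compound 1 to compound 2 cannot be read. Compound 3 `COc1cc(C2CCN(CC(N)=O)CC2)ccc1Nc1ncc2c(C)cc(-c3ccccc3N(C)S(C)(=O)=O)n2n1` differs from compound 2 by methyl in place of hydroxy on an aromatic carbon. Among the measured compounds shown here, no measured step bears on a methyl at this position, and the single measured step is unreadable; compound 2 stands at the limit with no number of its own. For compound 3 the expected step is therefore a step that the limit leaves unreadable from compound 2 to compound 3, with a fair chance that this assay again reports only a limit. Compound 3 is estimated at 0.08 h, with a range from 0.03 h to 0.3 h.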

Compound 3, half-life: 0.517 h
Compound 3: the middle estimate sits 6.5-fold (0.81 log units) below what was measured; measured number outside the range, above it.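

In this assay, among the compounds shown here, this aromatic carbon, two ring bonds from the ring nitrogen, now gives the first readable change: methyl in place of hydrogen gives an at least 6.1-fold higher number from compound 1 to compound 3 (0.79 log units; beyond the scatter), and methyl in place of hydroxy gives an at least 6.1-fold higher number from compound 2 to compound 3 (0.79 log units; beyond the scatter). Substitution alone does not decide the outcome, since compound 2, with hydroxy on the same carbon, stays at a limit while compound 3, with methyl, gives a number. Both steps are minimum sizes only, since neither starting compound has a number of its own: the limit of < 0.0834 h in this assay, at which 2 of the 3 values shown sit.

As far as these compounds go, how large the methyl effect truly is remains open. From the compounds shown here alone, it is also open whether a longer chain such as ethyl, a chlorine atom or an amine on this carbon would give a number like that of compound 3.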